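The source may hold more compounds than are shown below. What is called first, only, known or untested is meant among the compounds shown, and "the series" means these compounds.

Three compounds have been measured in a functional assay on HCT-116 cells (Homo sapiens) for inhibition, read by sulforhodamine B assay, with a stated time of 72 h; on this read-out higher numbers stand for weaker inhibition and lower numbers for stronger inhibition:

Compound 1 `O=C(/C=C/c1cn(-c2ccccc2)nc1-c1cccnc1)c1ccccc1` gives 2000 nM.
Compound 2 `COc1ccc(OC)c(C(=O)/C=C/c2cn(-c3ccccc3)nc2-c2cccnc2)c1` gives 1000 nM.
Compound 3 `COc1ccc(C(=O)/C=C/c2cn(-c3ccccc3)nc2-c2cccnc2)c(OC)c1` gives 1300 nM.

Compound 1 has the highest of the three numbers, yet both of its gaps to the others are within the scatter: a 2.0-fold lower number from compound 1 to compound 2 (0.30 log units; within the scatter), and a 1.5-fold lower number from compound 1 to compound 3 (0.19 log units; within the scatter). The gap between the two dimethoxy compounds is small as well: a 1.3-fold higher number from compound 2 to compound 3 (0.11 log units; within the scatter). On these numbers the three compounds cannot be told apart.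

Compound 4 `O=C(/C=C/c1cn(-c2ccccc2)nc1-c1ccncc1)c1ccccc1` has not yet been measured. It differs from compound 1 at one place: pyridin-4-yl in place of pyridin-3-yl on an aromatic carbon. All three measured steps alter the aryl group on the carbonyl carbon and leave the pyridinyl unchanged, so none of them bears on this change. Within the data shown here, the data hold no step that moves the nitrogen within the pyridinyl ring, and no other compound with a pyridin-4-yl group. Without a guide of that kind, the expectation for compound 4 in this assay is a step of no size beyond the scatter, in either direction, which means no change at the digits printed from compound 1 to compound 4 (within the scatter). Compound 4 is therefore estimated at 2000 nM, with a wide range from 700 nM to 6000 nM that reflects the absence of any matching step.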

Compound 4, half-maximal inhibitory concentration: 3100 nM
Compound 4: the middle estimate sits 1.6-fold (0.19 log units) below what was measured, within the range that was stated.
By their numbers in this assay, from the lowest: compounds 2, 3, 1 and 4 (each within the scatter of the next, the first and the last beyond it).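

In this assay, among these compounds, pyridin-4-yl in place of pyridin-3-yl gives a 1.6-fold higher number from compound 1 to compound 4 (0.19 log units; within the scatter), the first measured step at this position on the five-membered aromatic ring with 2 nitrogen. The earlier steps shown here all altered the aryl group on the carbonyl carbon, whereas this one shows that moving the pyridinyl nitrogen, with the same atoms and the same counts of donors and acceptors, leaves compound 1 and compound 4 impossible to tell apart on these numbers. No measurement at hand offers an explanation for this small step.

As far as these compounds go, it remains open whether this position tolerates a larger change, such as pyridin-2-yl, a plain phenyl, or a pyridinyl ring carrying an amine or a carboxylic acid. Also unresolved is whether pyridin-4-yl would give a similarly small step when the carbonyl carbon carries 2,5-dimethoxyphenyl, as in compound 2, or 2,4-dimethoxyphenyl, as in compound 3, rather than the phenyl group of compound 1.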